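Notes on swapping the biaryl group for furan

The source may report more compounds than this note shows. Statements on the series, on what has been measured and on what is new or still open speak of the compounds shown alone.

Compound 1 `COc1cc(CC(O)c2ccc(-c3cccc(C#N)c3)cc2)c([N+](=O)[O-])cc1OC` gives 5200 nM in an ADME assay on HeLa Rh cells (Homo sapiens) for cytotoxicity, read by microscopy; a higher number here means that more compound is tolerated, a lower number that less compound is tolerated
Compound 2 `COc1cc(CC(O)c2ccc(-c3cccc(CO)c3)cc2)c([N+](=O)[O-])cc1OC` gives 6000 nM in this assay

For the measured compounds named here, with only two numbers in hand, compound 2 at 6000 nM stands within the scatter of compound 1. The next structure, compound 3 `COc1cc(CC(O)c2ccc(-c3ccoc3)cc2)c([N+](=O)[O-])cc1OC`, carries furan-3-yl in place of 3-(hydroxymethyl)phenyl on an aromatic carbon para to a large group. Going by the values given here, the sole measured step is a 1.2-fold higher number from compound 1 to compound 2 (0.06 log units; within the scatter) for hydroxymethyl in place of cyano on an aromatic carbon. Among the compounds with values here, it bears only loosely on this change, as no measured pair covers the loss of the whole 3-(hydroxymethyl)phenyl. No step beyond the scatter is therefore expected in this assay, although the margin stays wide. The expected step is a 1.1-fold lower number from compound 2 to compound 3 (0.04 log units; within the scatter) and no larger. For compound 3 the estimated value is 5500 nM with an expected range of 2500 nM to 12000 nM for the coming measurement.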

Compound 3, half-maximal cytotoxic concentration: 5300 nM
Estimate against measurement, compound 3: 1.0-fold (0.02 log units) above; the range from low to high includes it.
By their numbers in this assay, from the lowest: compounds 1, 3 and 2 (each within the scatter of the next).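

The change to furan-3-yl gives a 1.1-fold lower number from compound 2 to compound 3 (0.05 log units; within the scatter) when it replaces 3-(hydroxymethyl)phenyl and a 1.0-fold higher number from compound 1 to compound 3 (0.01 log units; within the scatter) when it replaces 3-cyanophenyl in this assay on this aromatic carbon para to a large group. The earlier pair changed only a substituent on the six-membered aromatic ring, whereas these steps show that the whole ring can give way to a five-membered aromatic ring with 1 hetero atom, with compound 1, compound 2 and compound 3 all remaining within the scatter of one another. No evidence is available to explain this flat result.

On these data alone, whether an aliphatic amine, a carboxylic acid or a longer alkyl chain at this place would also leave the number within the scatter remains open. The compounds shown also leave open whether changes elsewhere on the shared core would behave in the same way.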